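The source may report more compounds than this note shows. Statements on the series, on what has been measured and on what is new or still open speak of the compounds shown alone.

Within the data shown here, in an ADME assay on microsomes from liver (Mus musculus) for metabolic stability, with a stated time of 10 min (on this read-out higher numbers stand for a more stable compound and lower numbers for a less stable compound), compound 1 `COC[C@]1(C(=O)N2CC[C@](c3ccc(C(F)(C(F)(F)F)C(F)(F)F)cc3)(S(=O)(=O)c3ccc(F)cc3)C2)CC[C@H](C(=O)O)CC1` gives 88%, the only number so far. Among the measured compounds shown here, compound 2 `O=C(N1CC[C@](c2ccc(C(F)(C(F)(F)F)C(F)(F)F)cc2)(S(=O)(=O)c2ccc(F)cc2)C1)C12CCC(C(=O)O)(CC1)OC2` is recorded as "not determined" (no result reported), so it has no place on the scale and offers no baseline for the step under review. Compound 3 `NC(=O)[C@H]1CC[C@H](C(=O)N2CC[C@](c3ccc(C(F)(C(F)(F)F)C(F)(F)F)cc3)(S(=O)(=O)c3ccc(F)cc3)C2)CC1` has yet to be measured.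

The structural change is a group of 9 heavy atoms (7 carbon, 1 nitrogen, 1 oxygen; one six-membered non-aromatic ring of carbon only) in place of a group of 11 heavy atoms (8 carbon, 3 oxygen; one six-membered non-aromatic ring of carbon only, one six-membered non-aromatic ring with 1 hetero atom), on a carbonyl carbon. A 4-carbamoylcyclohexyl group enters on a carbonyl carbon whose other neighbours are amide-type nitrogen in a ring, and the rest of the shared core stays as it is.

For the measured compounds named here, without a value for compound 2, the step itself cannot be sized from data, and the only available anchor is compound 1 at 88%. Against that anchor, the expected change in this assay is none beyond the usual scatter, with a slight lean downward, since that value already lies near the top of the scale. This remains a weak expectation, resting on a single measured compound. For compound 3 the estimated value is 82%, with an expected range from 60% to 96%.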

Compound 3, percent of the compound remaining: 100%
The estimate for compound 3 lay 18 percentage points below the measured number; the measured number lies above the stated range.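

In this assay, putting 4-carbamoylcyclohexyl in place of 4-carboxy-1-(methoxymethyl)cyclohexyl on a carbonyl carbon whose other neighbours are amide-type nitrogen in a ring gives a number 12 percentage points higher from compound 1 to compound 3 (beyond the scatter), so this position accepts the change with no loss on this read-out. Compound 3 carries neither a carboxylic acid nor a methoxymethyl group and gives 100%, which shows that, on the shared core, neither group is required for a high reading, and it leaves the read-out no visible room for a further rise. No step involving compound 2 can be read, as that compound has no value, and no supporting measurement is available to explain the rise in compound 3.

The step from compound 1 to compound 3 exchanges the carboxylic acid for the carboxamide and removes the methoxymethyl group together, so the share of each in the rise remains unresolved. Also open, on these data alone, is whether a primary amine or a hydroxyl group at the 4-position of the cyclohexyl group would hold the reading of compound 3 in this assay.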